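The compounds below may be only part of what the source reports. "The series", "measured", "known", "first", "only" and "open" are said of these compounds alone.

Compound 1 `CC1(C)CCN(c2ccc(C(=O)NS(=O)(=O)c3ccc(NC(C)(C)CSc4ccccc4)c([N+](=O)[O-])c3)cc2)CC1`, compound 2 `COC1(Cc2ccccc2Br)CCN(c2ccc(C(=O)NS(=O)(=O)c3ccc(N[C@H](CCN(C)C)CSc4ccccc4)c([N+](=O)[O-])c3)cc2)CC1` and compound 3 `CN(C)CC[C@H](CSc1ccccc1)Nc1ccc(S(=O)(=O)NC(=O)c2ccc(N3CCN(C(=O)Nc4ccccc4)CC3)cc2)cc1[N+](=O)[O-]` share one core and were tested in a functional assay (FL5.12 cells, Mus musculus) with Apoptosis regulator Bcl-2 (Homo sapiens) as the target; a lower number here means that less compound is needed, a higher number that more compound is needed for the effect. Compound 1 gives 2200 nM, and compound 2 gives 200 nM. Compound 3 reaches only (the limit of > 50000 nM in this assay, at which 1 of the 3 values shown sits); its entry of > 50000 nM is a limit of the assay, not a number. Compound 4 `CN(C)CC[C@H](CSc1ccccc1)Nc1ccc(S(=O)(=O)NC(=O)c2ccc(N3CCN(Cc4ccccc4C(F)(F)F)CC3)cc2)cc1[N+](=O)[O-]` has not been measured; it differs from compound 3 in one place: 2-(trifluoromethyl)benzyl in place of phenylcarbamoyl on an amine nitrogen in a ring. Among the compounds with values here, no measured pair shows this change, so its size is uncertain. A downward step is expected because compound 3 sits at > 50000 nM while compound 1 and compound 2 show that the shared core can reach measurable values. The expected step from compound 3 to compound 4 is an at least 8.3-fold lower number from compound 3 to compound 4 (0.92 log units; beyond the scatter). Compound 4 is therefore estimated at 6000 nM, within 800 nM to 40000 nM.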

Compound 4, half-maximal effective concentration: 130 nM
Compound 4: the middle estimate sits 46-fold (1.66 log units) above what was measured, outside the stated range (below it).
By their numbers in this assay, from the lowest: compounds 4 and 2 (each within the scatter of the next); then compound 1. At a limit, above all of these: compound 3.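

In this assay, putting 2-(trifluoromethyl)benzyl in place of phenylcarbamoyl on this amine nitrogen in a ring gives an at least 380-fold lower number from compound 3 to compound 4 (2.58 log units; beyond the scatter). The group on this one nitrogen can therefore separate a compound with a measurable value from one without. Compound 3 stands at a limit of the assay, not at a number, so the full size of the step stays unknown: the limit of > 50000 nM in this assay, at which 1 of the 4 values shown sits.

From the compounds shown here alone, it remains open which part of the change matters. A plain benzyl or a 2-chlorobenzyl on this nitrogen would show whether the trifluoromethyl is needed or whether replacing phenylcarbamoyl is enough.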